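Carboxy Replaces Chloro: What to Expect for Compound 4

A few compounds are considered here, and "the series" means these few. Any claim that something is new, unique, unknown or untested is made for them only; others in the source may bear on it.

Three compounds built on one shared core were tested in a functional assay on MDA-MB-231 cells (Homo sapiens) for cytotoxicity, read by MTT assay, with a stated time of 48 h; a lower number here means a stronger inhibitor, a higher number a weaker inhibitor. Compound 1 `O=C(/C=C/c1ccc2c(c1)B(O)OC2)c1ccc(Cl)cc1` gives 7900 nM, the highest number of the three. Compound 2 `O=C(/C=C/c1ccc2c(c1)B(O)OC2)c1ccccc1F` gives 2200 nM, and compound 3 `Cc1cccc(C(=O)/C=C/c2ccc3c(c2)B(O)OC3)c1` gives 4500 nM. Exchanging the ring on the carbonyl carbon gave a 3.6-fold lower number from compound 1 to compound 2 (0.56 log units; beyond the scatter) and a 1.8-fold lower number from compound 1 to compound 3 (0.24 log units; within the scatter). Compound 4 `O=C(O)c1ccc(C(=O)/C=C/c2ccc3c(c2)B(O)OC3)cc1` differs from compound 1 in one place: carboxy in place of chloro on an aromatic carbon. Among the measured compounds shown here, no measured step exchanges chloro for carboxy, so the earlier steps show only that changes on this ring move the number by modest amounts. For compound 4 the step is estimated as a 1.3-fold higher number from compound 1 to compound 4 (0.10 log units; within the scatter), a shift not far beyond the scatter. Compound 4 is expected to give about 10000 nM, within 3000 nM to 30000 nM.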

Compound 4, half-maximal inhibitory concentration: > 100000 nM
Compound 4 was reported as a limit (the forecaster's own chance of this, stated with the estimate: 15%); at least 10-fold (1.00 log units) between middle value and limit.
By their numbers in this assay, from the lowest: compound 2; then compounds 3 and 1 (each within the scatter of the next). At a limit, above all of these: compound 4.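

Until now, changes on this ring had moved the number only modestly, but carboxy in place of chloro, para to a large group, gives an at least 12-fold higher number from compound 1 to compound 4 (1.10 log units; beyond the scatter). Among the compounds shown here, this position therefore does not tolerate every group, and one exchange here can matter far more than the earlier steps suggested. Compound 4 is reported in this assay only as a limit, so the step gives a minimum and not a full size: the limit of > 100000 nM in this assay, at which 1 of the 4 values shown sits.

The compounds shown leave open whether a methyl ester or an amide at this position would give a number close to that of compound 1 or one as high as that of compound 4. They also leave open how an amine would behave here.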